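Moving the nitrooxyethyl group on the phenyl ester ring

The source may report more compounds than this note shows. Statements on the series, on what has been measured and on what is new or still open speak of the compounds shown alone.

Measured so far:
compound 1 `CCCCc1nc(Cl)c(COC(=O)CCCCO[N+](=O)[O-])n1Cc1ccc(-c2ccccc2-c2nn[nH]n2)cc1` gives 100% in a functional assay on the whole organism (aorta, strain Wistar) with Rattus norvegicus as the target; a higher number here means a larger maximal response, a lower number a smaller maximal response
compound 2 `CCCCc1nc(Cl)c(COC(=O)c2ccc(CO[N+](=O)[O-])cc2)n1Cc1ccc(-c2ccccc2-c2nn[nH]n2)cc1` gives 100%
compound 3 `CCCCc1nc(Cl)c(COC(=O)c2cccc(C(C)O[N+](=O)[O-])c2)n1Cc1ccc(-c2ccccc2-c2nn[nH]n2)cc1` gives 47%

Compound 3 stands lowest of the three numbers in this assay. Both other compounds reach the same level: no change at the digits printed from compound 1 to compound 2 (within the scatter). From there the drop to compound 3 is large in both cases, a number 53 percentage points lower from compound 1 to compound 3 (beyond the scatter) and a number 53 percentage points lower from compound 2 to compound 3 (beyond the scatter).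

Compound 4 `CCCCc1nc(Cl)c(COC(=O)c2ccc(C(C)O[N+](=O)[O-])cc2)n1Cc1ccc(-c2ccccc2-c2nn[nH]n2)cc1` is not yet measured. It differs from compound 3 in one place: 4-(1-(nitrooxy)ethyl)phenyl in place of 3-(1-(nitrooxy)ethyl)phenyl on a carbonyl carbon. Going by the values given here, the step that bears most on this is the one from compound 2 to compound 3, but that step exchanged two things at once, the 1-(nitrooxy)ethyl group for the (nitrooxy)methyl group and one ring pattern for another. Compound 4 keeps the 1-(nitrooxy)ethyl group of compound 3 but carries it as 4-(1-(nitrooxy)ethyl)phenyl, the same ring pattern as the 4-((nitrooxy)methyl)phenyl of compound 2. The data do not separate the two parts of the drop. A partial recovery toward the level of compound 2 is therefore expected, with wide uncertainty. The expected step is a number 28 percentage points higher from compound 3 to compound 4 (beyond the scatter). Compound 4 is estimated at 75%, with a range from 45% to 100%.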

Compound 4, largest response reached (Emax), in percent of the reference or control that the assay uses: 100%
Estimate against measurement, compound 4: 25 percentage points below, within the range that was stated.
By their numbers in this assay, from the lowest: compound 3; then compounds 1, 2 and 4 (each within the scatter of the next).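

In this assay, going by these compounds alone, the only change between the two isomers is where the 1-(nitrooxy)ethyl group sits, and it gives a number 53 percentage points higher from compound 3 to compound 4 (beyond the scatter), so the ring pattern alone can account for a step of this size. Within the data shown here, the added methyl can be read on its own for the first time, and methyl in place of hydrogen on the saturated chain carbon gives no change at the digits printed from compound 2 to compound 4 (within the scatter), which removes that methyl as a sufficient explanation for the low value of compound 3 in this assay, at least when the group is carried as 4-(1-(nitrooxy)ethyl)phenyl. The aromatic ester also matches the open chain, with no change at the digits printed from compound 1 to compound 4 (within the scatter), so the low value stands out as particular to 3-(1-(nitrooxy)ethyl)phenyl among the groups shown on this carbonyl carbon.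

From the compounds shown here alone, it remains open whether 3-((nitrooxy)methyl)phenyl would give the same low value, which would show whether the methyl plays any part in that ring pattern, and whether an ethyl group on the same chain carbon or a longer chain between the ring and the nitrooxy group would change the value of compound 4. The compounds shown come with no measurement that explains the gap between the two ring patterns.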